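The compounds below may be only part of what the source reports. "The series", "measured", "known", "first", "only" and "open" are said of these compounds alone.

Compound 1 `COc1cc(NS(=O)(=O)c2ccc(N3CCNC3=O)cc2)cc(OC)c1OC`: in a functional assay on P388D1 cells (Homo sapiens) for antiproliferative activity, read by sulforhodamine B assay, with a stated time of 48 h (on this read-out higher numbers stand for weaker inhibition and lower numbers for stronger inhibition), compound 1 gives 38 nM.
Compound 2 `COc1cccc(NS(=O)(=O)c2ccc(N3CCNC3=O)cc2)c1`: in this assay compound 2 gives 250 nM.

Of these two numbers in this assay, compound 2 stands highest; compound 1 lies below it by a gap beyond the usual scatter. Compound 3 `Cc1cccc(NS(=O)(=O)c2ccc(N3CCNC3=O)cc2)c1` differs from compound 2 by methyl in place of methoxy on an aromatic carbon. Going by the values given here, no measured pair shows this change, so its effect cannot be read from the data. For compound 3 a small move toward a higher number is expected, a 1.6-fold higher number from compound 2 to compound 3 (0.20 log units; within the scatter), close to the scatter. Compound 3 is estimated at 400 nM in this assay, within a range of 150 nM to 1200 nM.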

Compound 3, half-maximal inhibitory concentration: 250 nM
The estimate for compound 3 lay 1.6-fold (0.20 log units) above the measured number; measured number inside the range.
By their numbers in this assay, from the lowest: compound 1; then compounds 2 and 3 (each within the scatter of the next).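

In this assay, the 3-methylphenyl group does as well as the 3-methoxyphenyl group, with no change at the digits printed from compound 2 to compound 3 (within the scatter) for methyl in place of methoxy. At this position, then, the oxygen of the methoxy group and the hydrogen-bond acceptor it counts are not needed to keep the number. No independent measurement here accounts for this result.

As far as these compounds go, whether an amine, a carboxylic acid or a longer chain would be tolerated at this position remains open. So does whether methyl could likewise replace a methoxy group in compound 1.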